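The compounds below may be only part of what the source reports. "The series", "measured", "known", "first", "only" and "open" are said of these compounds alone.

Measured in an ADME assay on Vero cells (Chlorocebus sabaeus) for cytotoxicity, read by MTT assay, with a stated time of 72 h; a higher number here means a weaker inhibitor, a lower number a stronger inhibitor:
- compound 1 `COc1ccc(NC(=S)NNC(=O)c2cc([N+](=O)[O-])c[nH]2)cc1`: 331000 nM
- compound 2 `Cn1cc([N+](=O)[O-])cc1C(=O)NNC(=O)NCc1ccco1`: 482000 nM
- compound 3 `COc1ccc(NC(=O)NNC(=O)c2cc([N+](=O)[O-])c[nH]2)cc1`: 401000 nM

Among the compounds with values here, all three numbers in this assay fall within the usual scatter of one another; compound 1 is not distinguished from compound 3 or from compound 2, and no step between measured compounds is available to anchor a direction. Compound 4 `O=C(NNC(=S)Nc1ccc([N+](=O)[O-])cc1)c1cc([N+](=O)[O-])c[nH]1` is not yet measured. It differs from compound 1 as follows: nitro in place of methoxy on an aromatic carbon. Within the data shown here, with no measured step to lean on and the whole set sitting in the same weak range, the expected step from compound 1 to compound 4 in this assay is a 1.1-fold lower number from compound 1 to compound 4 (0.04 log units; within the scatter), that is, none beyond the scatter. Compound 4 is therefore estimated at 300000 nM, with a range from 150000 nM to 600000 nM.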

Compound 4, half-maximal inhibitory concentration: 529000 nM
Compound 4: the middle estimate sits 1.8-fold (0.25 log units) below what was measured, within the range that was stated.
By their numbers in this assay, from the lowest: compounds 1, 3, 2 and 4 (each within the scatter of the next).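

In this assay, within the data shown here, nitro in place of methoxy on an aromatic carbon, para to a large group, gives a 1.6-fold higher number from compound 1 to compound 4 (0.20 log units; within the scatter) and so supplies the first step. At this position on the six-membered aromatic ring of carbon only, the two groups are not told apart, and compound 4 stays in the same weak range as compound 1. No measurement on hand bears on what lies behind this step.

Going by these compounds, whether an amine or a carboxylic acid on this carbon would move the number beyond the scatter remains open. Also open, on these data alone, is whether any other place on the shared core responds more strongly.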